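Widening the Methoxy Pattern on a Triazole-Linked Triterpenoid

The source may report more compounds than this note shows. Statements on the series, on what has been measured and on what is new or still open speak of the compounds shown alone.

Of the compounds shown here, two have so far been tested in a functional assay on HepG2 cells (Homo sapiens) for cytotoxicity, read by MTT assay, with a stated time of 48 h; on this read-out lower numbers stand for stronger inhibition and higher numbers for weaker inhibition. Compound 1 `CC(C)=CCC/C(C)=C/CC/C(C)=C/CC[C@@H]1[C@@]2(C)CC/C(=N\OCc3cn(-c4cccc([N+](=O)[O-])c4)nn3)C(C)(C)[C@@H]2CC[C@@]1(C)O` gives 22000 nM in this assay. Compound 2 `COc1cccc(-n2cc(COc3ccc(/C=C4\C[C@]5(C)[C@@H](CC/C=C(\C)CC/C=C(\C)CCC=C(C)C)[C@](C)(O)CC[C@H]5C(C)(C)C4=O)cc3)nn2)c1` gives 50100 nM in this assay, the higher of the two numbers and thus the weaker inhibitor of the pair. The difference between compound 2 and compound 1 lies beyond the usual scatter of repeated measurements.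

Compound 3 `COc1cc(OC)c(-n2cc(COc3ccc(/C=C4\C[C@]5(C)[C@@H](CC/C=C(\C)CC/C=C(\C)CCC=C(C)C)[C@](C)(O)CC[C@H]5C(C)(C)C4=O)cc3)nn2)c(OC)c1` differs from compound 2 in a single place: 2,4,6-trimethoxyphenyl in place of 3-methoxyphenyl on an aromatic nitrogen. Going by the values given here, no two measured compounds differ from each other in one place, so there is no earlier step of the same kind to compare with. The change adds two more methoxy groups on the same aromatic ring while the rest of the molecule stays unchanged, and the step from compound 2 to compound 3 is expected to be small, a 1.1-fold lower number from compound 2 to compound 3 (0.05 log units; within the scatter), likely within the scatter. Compound 3 is therefore estimated at about 45000 nM, with a range from 20000 nM to 110000 nM.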

Compound 3, half-maximal inhibitory concentration: 57500 nM
Compound 3: the middle estimate sits 1.3-fold (0.11 log units) below what was measured, within the range that was stated.
By their numbers in this assay, from the lowest: compound 1; then compounds 2 and 3 (each within the scatter of the next).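

In this assay, going by these compounds alone, replacing 3-methoxyphenyl with 2,4,6-trimethoxyphenyl on the aromatic nitrogen of the five-membered ring gives a 1.1-fold higher number from compound 2 to compound 3 (0.06 log units; within the scatter) as the first single-place step in this set. It shows that this position can carry a group of 12 heavy atoms and 3 hydrogen-bond acceptors, in place of one with 8 heavy atoms and 1 hydrogen-bond acceptor, with no difference that can be told from the scatter. No measurement at hand offers an explanation for this result.

Both compounds carry only methoxy groups on this phenyl ring, so this pair cannot show whether an amine or a carboxylic acid there would give a difference beyond the scatter. It also leaves open what a plain methyl in place of the whole ring would give.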